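This account rests on a few compounds, and the source may have more. Where it says the series, first, only, none or still open, it means among the compounds named here.

Compound 1 `C=C(C)COc1ccc(C(=O)Nc2cccc(C)n2)cc1`: 24700 nM in an in vitro assay on HEK-tsA201 cells for antagonist activity at Neuronal acetylcholine receptor; alpha3/beta4 (Homo sapiens), read by fluorescence and calcium flux; a lower number here means a stronger inhibitor, a higher number a weaker inhibitor
Compound 2 `C=CCOc1ccc(C(=O)Nc2ccccn2)cc1`: 61400 nM in this assay

Among the compounds with values here, compound 1 holds the lower of the two numbers in this assay; compound 2 sits beyond the scatter from it, though the two differ in more than one place and no single step joins them. Compound 3 `CCCOc1ccc(C(=O)Nc2cccc(C)n2)cc1` is the untested neighbour of compound 1, carrying (ethyl in place of 1-methylethenyl on a saturated chain carbon bound to an oxygen on an aromatic ring). Nothing measured here speaks to that exchange, so only a small step is expected in this assay, in either direction and likely within the scatter, as a 1.0-fold higher number from compound 1 to compound 3 (0.01 log units; within the scatter). Compound 3 is expected to give about 25000 nM, between 8000 nM and 80000 nM.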

Compound 3, half-maximal inhibitory concentration: 11100 nM
Compound 3: middle estimate off by 2.3-fold (0.35 log units), on the high side; the measured number falls inside the stated range.
By their numbers in this assay, from the lowest: compound 3; then compound 1; then compound 2.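

In this assay, this position responds to a single exchange: ethyl in place of 1-methylethenyl, on a saturated chain carbon bound to an oxygen on an aromatic ring, gives a 2.2-fold lower number from compound 1 to compound 3 (0.35 log units; beyond the scatter). The double bond outside aromatic rings is therefore not required for inhibition at this level. Nothing available explains why the number falls. As far as these compounds go, whether a longer chain such as butoxy, or an amine on the propoxy chain, would lower the number further remains open. Compound 2 differs from compound 3 in more than one place, so this comparison does not isolate the effect of any other part of the core.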